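This account rests on a few compounds, and the source may have more. Where it says the series, first, only, none or still open, it means among the compounds named here.

Measured so far:
Compound 1, `COC1=C(OC)C(=O)C(CCCCCCn2cc(C[C@H](O)COCCOC[C@@H](O)Cc3ccc(-c4ccccc4)cc3)nn2)=C(C)C1=O`: 5000 nM
Compound 2, `O[C@H](COCCOC[C@@H](O)Cc1c[nH]nn1)Cc1ccc(-c2ccccc2)cc1`: > 100000 nM

In a functional assay on HCT-116 cells (Homo sapiens) for inhibition, read by MTT assay, with a stated time of 72 h (on this read-out higher numbers stand for weaker inhibition of growth and lower numbers for stronger inhibition of growth), compound 1, which carries a long chain ending in a quinone on the triazole nitrogen, gives 5000 nM. Compound 2, which has only hydrogen on that nitrogen, gives > 100000 nM in this assay, and this is a limit of the assay, not a number. Compound 2 therefore stands at the limit of > 100000 nM in this assay, at which 1 of the 2 values shown sits, the weakest end of what this assay reports, with no numeric value of its own.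

Compound 3, `O[C@H](COCCOC[C@@H](O)Cc1cn(-c2ccc3[nH]ccc3c2)nn1)Cc1ccc(-c2ccccc2)cc1`, differs from compound 2 by 1H-indol-5-yl in place of hydrogen on an aromatic nitrogen. The two measured compounds show that the bare triazole gives only a limit while a substituted triazole nitrogen gives a measurable value; nothing else about the size of such a change is known here. It is expected that the change from compound 2 to compound 3 brings the value into the measurable range, so that the step of an at least 5.0-fold lower number from compound 2 to compound 3 (0.69 log units; beyond the scatter) goes toward stronger inhibition, though with wide uncertainty. For compound 3 the estimate in this assay is 20000 nM, within a range from 3000 nM to 100000 nM.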

Compound 3, concentration for 50% growth inhibition: 15500 nM
Compound 3: the middle estimate sits 1.3-fold (0.11 log units) above what was measured, and the stated range covers the measured number.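

In this assay, 1H-indol-5-yl in place of hydrogen on an aromatic nitrogen gives an at least 6.4-fold lower number from compound 2 to compound 3 (0.80 log units; beyond the scatter), so this nitrogen tolerates a directly attached two-ring aromatic group and the change goes toward stronger inhibition of growth. Among the compounds shown here, until now, the only measurable value belonged to a compound with a long chain ending in a quinone at this position, whereas compound 3 reaches the measurable range with no quinone at all, which shows that a quinone is not needed for a numeric value in this assay. The step gives only a lower bound on the size of the change because compound 2 is held at a limit and has no number of its own: the limit of > 100000 nM in this assay, at which 1 of the 3 values shown sits.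

The compounds shown leave open whether the gain depends on the 1H-indol-5-yl group in particular, or whether a plain phenyl, a methyl or a simple hexyl chain at this nitrogen would also give a measurable value. They also leave open what the indole ring hydrogen contributes, and whether a methyl group on that ring nitrogen or an amine on the six-membered ring would change the value.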